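A single fluorine in place of a larger group

The source may report more compounds than this note shows. Statements on the series, on what has been measured and on what is new or still open speak of the compounds shown alone.

Measured in a functional assay on CWR22R cells (Homo sapiens) for antiproliferative activity, read by propidium iodide staining, with a stated time of 96 h; a lower number here means a stronger inhibitor, a higher number a weaker inhibitor:
Compound 1 `CC(O)(CS(=O)(=O)c1ccc(S(F)(F)(F)(F)F)cc1)C(=O)Nc1ccc(S(F)(F)(F)(F)F)cc1` gives 17300 nM.
Compound 2 `CC(O)(CS(=O)(=O)c1ccc(F)cc1)C(=O)Nc1ccc(S(F)(F)(F)(F)F)cc1` gives 20600 nM.
Compound 3 `CC(O)(CS(=O)(=O)c1ccc(S(F)(F)(F)(F)F)cc1)C(=O)Nc1cccc(S(F)(F)(F)(F)F)c1` gives 12300 nM.

Compound 1 and compound 2 differ in one place: one fluorine atom in place of a group of 6 heavy atoms (5 fluorine, 1 sulfur; no ring), on an aromatic carbon. That change produced a 1.2-fold higher number from compound 1 to compound 2 (0.08 log units; within the scatter), so the two numbers cannot be told apart with confidence. Compound 3 is built from the same atoms as compound 1, joined differently; the difference between the two cores is not broken down here. The numbers of compound 3 and compound 1, and of compound 3 and compound 2, also lie within the scatter of one another, so no order among the three can be claimed.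

Compound 4 `CC(O)(CS(=O)(=O)c1ccc(F)cc1)C(=O)Nc1cccc(S(F)(F)(F)(F)F)c1` has not yet been measured. It arises from compound 3 by the same change seen before: one fluorine atom in place of a group of 6 heavy atoms (5 fluorine, 1 sulfur; no ring), on an aromatic carbon. The place is described in exactly the same words for both pairs, so this is the same change, not merely one of the same kind. Because the earlier step gave a 1.2-fold higher number from compound 1 to compound 2 (0.08 log units; within the scatter), a step of about that size is expected here, a 1.2-fold higher number from compound 3 to compound 4 (0.07 log units; within the scatter). Compound 4 is therefore expected to give 14500 nM, estimated to fall between 7000 nM and 30000 nM.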

Compound 4, half-maximal inhibitory concentration: 38900 nM
The estimate for compound 4 lay 2.7-fold (0.43 log units) below the measured number, outside the stated range (above it).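

In this assay, putting one fluorine in place of the larger group gave a 3.2-fold higher number from compound 3 to compound 4 (0.50 log units; beyond the scatter), so on this core the change can be read as a real loss of strength. Set beside the earlier step, however, it does not prove that the core alters the effect of the change, since the gap between the two steps is too small to separate them: the same change on two cores in this assay, a 1.2-fold higher number (0.08 log units; within the scatter) from compound 1 to compound 2 and a 3.2-fold higher number (0.50 log units; beyond the scatter) from compound 3 to compound 4, 2.7-fold (0.42 log units) apart, within the scatter of two such steps

Among the compounds shown here, with only two pairs, the result shows that a step read on one core is a rough guide to the next core, not a firm rule, and it gives no reason for the difference in the two readings.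

The compounds shown leave open whether other groups on that aromatic carbon, such as a nitrile, a trifluoromethyl or an amine, would behave like the fluorine or like the larger group. They also leave open how the same change would behave on a third core.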